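Removing one ester from a seven-membered ring: expected cytotoxicity

The compounds below may be only part of what the source reports. "The series", "measured", "known", "first", "only" and "open" are said of these compounds alone.

Two members of the series have been measured in a functional assay on HONE1 cells for cytotoxicity against HONE1 cell line (Homo sapiens), read by MTT assay, with a stated time of 48 h; on this read-out lower numbers stand for stronger inhibition and higher numbers for weaker inhibition. Compound 1 `C=C1C(=O)O[C@@H]2[C@@H]3[C@@]4(C=C[C@@]3(C)[C@]3(C4)C(=O)O[C@@H]4[C@H]5C(C)=CC[C@H]5[C@](C)(O)C[C@H](O)[C@H]43)[C@](C)(O)CC[C@@H]12` gives in this assay only a limit, > 10000 nM, and not a number; this is the limit of > 10000 nM in this assay, at which 1 of the 2 values shown sits. Among the measured compounds shown here, compound 2 `C=C1C(=O)O[C@H]2[C@H]1[C@@H](OC(=O)/C(C)=C/C)C[C@@](C)(O)[C@]13C=C[C@](C)([C@H]21)[C@]1(C3)C(=O)O[C@@H]2[C@H]3C(C)=CC[C@H]3[C@](C)(O)C[C@H](OC(=O)/C(C)=C/C)[C@H]21` gives 3500 nM in this assay, the only number among the two values shown. For the measured compounds named here, no pair of measured compounds differing in one place is available, so no measured step can be read from the series as it stands.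

Compound 3 `C=C1C(=O)O[C@@H]2[C@@H]3[C@@]4(C=C[C@@]3(C)[C@]3(C4)C(=O)O[C@@H]4[C@H]5C(C)=CC[C@H]5[C@](C)(O)C[C@H](OC(=O)/C(C)=C/C)[C@H]43)[C@](C)(O)CC[C@@H]12` is next to be measured in this assay. Relative to compound 2 the change is hydrogen in place of ((1-methylprop-1-en-1-yl)carbonyl)oxy on a saturated ring carbon. The values of compound 1 and compound 2 give the frame: one a limit, the other a number. For the step in this assay from compound 2 to compound 3 a weakening is expected, a 2.0-fold higher number from compound 2 to compound 3 (0.30 log units; within the scatter), modest and not surely beyond the scatter. Compound 3 is accordingly expected near 7000 nM in this assay, within 3000 nM to 20000 nM, with a real chance that only a limit is returned.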

Compound 3, half-maximal inhibitory concentration: > 10000 nM
Compound 3 gave a limit, no number (the forecaster's own chance of this, stated with the estimate: 35%); middle value at least 1.4-fold (0.15 log units) away from the limit.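

In this assay, among the compounds shown here, hydrogen in place of ((1-methylprop-1-en-1-yl)carbonyl)oxy on a saturated ring carbon of the seven-membered ring gives an at least 2.8-fold higher number from compound 2 to compound 3 (0.45 log units; beyond the scatter), the first measured one-place step and the first sign that the read-out is sensitive to the group at this position. Compound 3 gives > 10000 nM, which is a limit and not a number, so the step sets only a lower bound on the size of this change. The step between compound 1 and compound 3 cannot be read, leaving the contribution of the ester retained in compound 3 undefined, and the series now sits largely at the same limit: the limit of > 10000 nM in this assay, at which 2 of the 3 values shown sit.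

The compounds shown do not separate a need for this particular ester from a need for any group on this carbon, since a free hydroxy, an acetate, a longer-chain ester and an amine at this position are not among them. Going by these compounds, how far compound 3 lies beyond its limit also remains open, as does the effect of this change with the other ester absent.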